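Alkynyl thiazole amides as mGlu5 negative modulators: amide variation

This account rests on a few compounds, and the source may have more. Where it says the series, first, only, none or still open, it means among the compounds named here.

Measured so far:
- compound 2, `CCC(=O)N1CCc2nc(C#Cc3ccccc3)sc2C1`: 38 nM
- compound 3, `O=S(=O)(C1CCCCC1)N1CCc2nc(C#Cc3ccccc3)sc2C1`: 480 nM
- compound 1, `COc1ccccc1C#Cc1nc2c(s1)C(=O)NCC2`: > 10000 nM

In an assay on HEK293 cells for negative allosteric modulation of metabotropic glutamate receptor 5 (Homo sapiens), read by FLIPR, with a stated time of 1 h (on this read-out higher numbers stand for weaker inhibition and lower numbers for stronger inhibition), compound 2 gives 38 nM, the lowest of the two numbers obtained. Compound 3 gives 480 nM in this assay, a weaker result that lies beyond the scatter of the method. Compound 1 reaches only (the limit of > 10000 nM in this assay, at which 1 of the 3 values shown sits), which is a limit of this assay and not a number.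

Compound 4, `O=C(N1CCCCC1)N1CCc2nc(C#Cc3ccccc3)sc2C1`, has not yet been run in this assay. It differs from compound 2 in one place, (piperidin-1-yl in place of ethyl on a carbonyl carbon), so that the propanoyl group becomes a (piperidin-1-yl)carbonyl group. Going by the values given here, no measured pair shows this kind of change, so the size of the step rests on an expectation only: the larger acyl group of compound 3 gave a weaker number than compound 2, and a modest loss in the same direction is expected here. Compound 4 is therefore estimated at 150 nM, within 40 nM to 600 nM, which would mean a step of a 3.9-fold higher number from compound 2 to compound 4 (0.60 log units; beyond the scatter).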

Compound 4, half-maximal inhibitory concentration: > 10000 nM
Compound 4 gave a limit, no number; the forecaster's own chance of this, stated with the estimate: 5%; at least 66-fold (1.82 log units) between middle value and limit.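

On the carbonyl carbon whose other neighbours are the amide-type nitrogen in a ring, replacing ethyl with piperidin-1-yl in this assay gives an at least 260-fold higher number from compound 2 to compound 4 (2.42 log units; beyond the scatter), a size that rests on a limit and not on a number. Going by these compounds alone, this is the first step that changes one place only, and it shows that a single replacement at this position can take activity out of the measurable range. Compound 4 therefore stands at the assay limit: the limit of > 10000 nM in this assay, at which 2 of the 4 values shown sit.

The compounds shown do not tell whether the loss goes with the piperidine ring itself or with the ring nitrogen bound to the carbonyl carbon. Cyclohexyl, which keeps a six-membered ring without that nitrogen, and dimethylamino, which keeps the nitrogen without a ring, would separate these two readings.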